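Swapping Trifluoromethoxy for Acetamido on an Aromatic Carbon

A few compounds are considered here, and "the series" means these few. Any claim that something is new, unique, unknown or untested is made for them only; others in the source may bear on it.

Values in a functional assay on blood (Homo sapiens), with a stated time of 60 min, in the presence of a further agent that is not named here; a lower number here means that less compound is needed, a higher number that more compound is needed for the effect:
- compound 1 `O=S(=O)(c1ccc(Oc2ccc(OC(F)(F)F)cc2)cc1)C1(CO)CCC2(CCNCC2)C1`: > 15000 nM (a limit)
- compound 2 `Nc1ccccc1NC(=O)C1(S(=O)(=O)c2ccc(Oc3ccc(OC(F)(F)F)cc3)cc2)CCC2(CCNCC2)C1`: 900 nM
- compound 3 `CNC(=O)NC(=O)C1(S(=O)(=O)c2ccc(Oc3ccc(OC(F)(F)F)cc3)cc2)CCC2(CCNCC2)C1`: < 400 nM (a limit)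

Within the data shown here, compound 2, at 900 nM, holds the only actual number in this small set. The other two values are limits of this assay. The next compound to be tested is compound 4 `CC(=O)Nc1ccc(Oc2ccc(S(=O)(=O)C3(C(=O)Nc4ccccc4N)CCC4(CCNCC4)C3)cc2)cc1`. It keeps the (2-aminophenyl)carbamoyl group of compound 2 and differs at the far aromatic end, with acetamido in place of trifluoromethoxy on an aromatic carbon.

Two measured steps start or end at compound 2. One is large, an at least 16-fold lower number from compound 1 to compound 2 (1.22 log units; beyond the scatter), and the other is at least modest, an at least 2.2-fold lower number from compound 2 to compound 3 (0.35 log units; beyond the scatter). Both lie beyond the scatter, but both concern the group on the saturated ring carbon or on the amide-type nitrogen. Among the measured compounds shown here, all three measured compounds carry trifluoromethoxy, so no measured step shows what replacing it does.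

With no measured guide to size or direction, the central expectation stays close to compound 2, though with wide uncertainty. The expected change is a 1.3-fold higher number from compound 2 to compound 4 (0.12 log units; within the scatter), which would not lie beyond the scatter. For compound 4 the estimated value is 1200 nM, with an expected range from 250 nM to 6000 nM.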

Compound 4, half-maximal effective concentration: 3700 nM
Compound 4: the middle estimate sits 3.1-fold (0.49 log units) below what was measured; measured number inside the range.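

In this assay, the far aromatic end proves to be a position that matters: with the (2-aminophenyl)carbamoyl group held in place, acetamido in place of trifluoromethoxy gives a 4.1-fold higher number from compound 2 to compound 4 (0.61 log units; beyond the scatter). Among these compounds, all the earlier compounds carried trifluoromethoxy, so this is the first measured reading of any change at this place, on an aromatic carbon para to a large group, and it shows both a direction and a size, with the step lying beyond the scatter. Nothing shown here gives a measured reason for this step.

Among the compounds shown here, what remains open is whether this change would act in the same direction and to a similar extent with the (methylcarbamoyl)carbamoyl group of compound 3 in place of the (2-aminophenyl)carbamoyl group, since the single pair of compound 2 and compound 4 is all that speaks to it. On these data alone, it is also open how other groups at this place would read, such as a free amine, a carboxylic acid or a simple methoxy group, and whether acetamido and trifluoromethoxy mark the ends of what this position allows.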